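This account rests on a few compounds, and the source may have more. Where it says the series, first, only, none or still open, it means among the compounds named here.

Compound 1 `O=C1N=C(N2N=C(c3ccccc3)CC2c2ccccc2O)S/C1=C1/C(=O)Nc2ccccc21` is the starting point. In a functional assay on cells (Cancer cell lines, Homo sapiens) for cytotoxicity, read by sulforhodamine B assay, with a stated time of 48 h (on this read-out lower numbers stand for stronger inhibition of growth and higher numbers for weaker inhibition of growth), compound 1 gives 5370 nM. Compound 2 `O=C1N=C(N2N=C(c3ccccc3)CC2c2ccccc2O)S/C1=C1/C(=O)Nc2ccc(Br)cc21` differs from it by one change (bromo in place of hydrogen on an aromatic carbon); in this assay compound 2 gives 720 nM, and the result was a step of a 7.5-fold lower number from compound 1 to compound 2 (0.87 log units; beyond the scatter), a clear move towards stronger growth inhibition.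

Compound 3 `COc1ccc(C2=NN(C3=NC(=O)/C(=C4\C(=O)Nc5ccccc54)S3)C(c3ccc(OC)cc3)C2)cc1` belongs to a second series; the difference between the core of compound 1 and the core of compound 3 is not broken down here. In this assay compound 3 gives 89200 nM, the highest value of the three measured compounds and therefore the weakest growth inhibition among them.

Compound 4 `COc1ccc(C2=NN(C3=NC(=O)/C(=C4\C(=O)Nc5ccc(Br)cc54)S3)C(c3ccc(OC)cc3)C2)cc1` carries the same change on the core of compound 3 (bromo in place of hydrogen on an aromatic carbon), at a place described in exactly the same words as for compound 2. Because the earlier step was a 7.5-fold lower number from compound 1 to compound 2 (0.87 log units; beyond the scatter), a step of similar size is expected here, though the two cores differ and the second series has only one measured member. The expected step is a 5.0-fold lower number from compound 3 to compound 4 (0.70 log units; beyond the scatter). In this assay compound 4 is estimated to give 18000 nM, within a range of 5000 nM to 60000 nM.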

Compound 4, concentration for total growth inhibition: 405 nM
Beside the measured number, compound 4's estimate is 44-fold (1.65 log units) above it; the whole stated range lies above it.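

In this assay, placing the bromo group on the second core gave a 220-fold lower number from compound 3 to compound 4 (2.34 log units; beyond the scatter), so the same swap of hydrogen for bromo moved the number in the same direction on both cores, but the size of the step did not carry over: the same change on two cores in this assay, a 7.5-fold lower number (0.87 log units; beyond the scatter) from compound 1 to compound 2 and a 220-fold lower number (2.34 log units; beyond the scatter) from compound 3 to compound 4, 30-fold (1.47 log units) apart, beyond the scatter of two such steps. The direction held in both available pairs, which makes bromo at this aromatic carbon a change worth trying on these two cores, whereas a step measured on one core proved a poor guide to the size of the step on the other. These two pairs do not show why the steps differ, nor which part of the cores matters, and they cannot predict the step on a third core.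

The compounds shown leave open whether a chloro group, a methyl group or an amine on the same aromatic carbon would also lower the number. They also leave open whether any such step would again depend on the core.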